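The source may hold more compounds than are shown below. What is called first, only, known or untested is meant among the compounds shown, and "the series" means these compounds.

Of the compounds shown here, three sharing one core have been measured in an ADME assay on microsomes from liver (Homo sapiens) for metabolic stability, tested at 2.5 uM; a lower number here means slower removal, a higher number faster removal of the compound. Compound 1 `O=S(=O)(c1ccc(F)cc1)c1cnc2c(F)cccc2c1-c1cccc(F)c1` gives 1.56 mL/min. Compound 2 `COc1cccc(-c2c(S(=O)(=O)c3ccc(F)cc3)cnc3c(F)cccc23)c1` gives 2.23 mL/min, and compound 3 `O=S(=O)(c1ccc(F)cc1)c1cnc2c(F)cccc2c1-c1cccc(Cl)c1` gives 1.21 mL/min. Compound 2 holds the highest of the three numbers, yet each gap to it lies within the scatter: a 1.4-fold higher number from compound 1 to compound 2 (0.16 log units; within the scatter), and a 1.8-fold lower number from compound 2 to compound 3 (0.27 log units; within the scatter). The remaining step, a 1.3-fold lower number from compound 1 to compound 3 (0.11 log units; within the scatter), is likewise within the scatter, so the three compounds cannot be told apart on these numbers.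

Compound 4 `COc1cccc(-c2c(S(=O)(=O)c3cccc(F)c3)cnc3c(F)cccc23)c1` has not yet been measured. It differs from compound 2 in 3-fluorophenyl in place of 4-fluorophenyl on a sulfonyl sulfur. None of the three measured steps touches the group on the sulfonyl sulfur; each of them exchanges a group on an aromatic carbon of a different part of the molecule, and every one of them stayed within the scatter. Going by the values given here, no measured step therefore bears directly on this change, and nothing among the three compounds points to a move beyond the scatter in this assay. The expected step is a 1.0-fold lower number from compound 2 to compound 4 (0.01 log units; within the scatter). Compound 4 is accordingly estimated at 2.2 mL/min, with a range from 1.2 mL/min to 4 mL/min.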

Compound 4, intrinsic clearance in a liver preparation (reported as CLH), per the amount of preparation that the assay uses: 2.6 mL/min
Compound 4: middle estimate off by 1.2-fold (0.07 log units), on the low side, and the stated range covers the measured number.
By their numbers in this assay, from the lowest: compounds 3, 1, 2 and 4 (each within the scatter of the next, the first and the last beyond it).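

Putting 3-fluorophenyl in place of 4-fluorophenyl on a sulfonyl sulfur gives a 1.2-fold higher number from compound 2 to compound 4 (0.07 log units; within the scatter) in this assay. Going by these compounds alone, this is the first step read at this part of the molecule, since the earlier steps all exchanged a group on an aromatic carbon elsewhere, and a swap that keeps the same atoms but joins them differently also stays within the scatter. No measurement is at hand that would explain this result.

The two groups compared here are both fluorophenyl, so the compounds shown leave open whether this position tolerates anything more different. An amine or a carboxylic acid on that ring, or a longer chain on the sulfonyl sulfur in place of the ring, could still give a step beyond the scatter.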